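Paired cyclic amidine groups: cytotoxicity across the series

A few compounds are considered here, and "the series" means these few. Any claim that something is new, unique, unknown or untested is made for them only; others in the source may bear on it.

Three compounds of a common design are measured. A fourth is not yet measured. Compound 1 `c1ccc(Oc2ccc(NC3=NCCN3)cc2)cc1` and compound 2 `c1ccc(Nc2ccc(NC3=NCCN3)cc2)cc1` share two six-membered aromatic rings with the five-membered ring group on one of them; how the two cores differ is not broken down here. Compound 3 `c1cc(Nc2ccc(NC3=NCCN3)cc2)ccc1NC1=NCCN1` carries a second such group on the core of compound 2, and compound 4 `c1cc(Oc2ccc(NC3=NCCN3)cc2)ccc1NC1=NCCN1` carries the same group on the core of compound 1.

In an ADME assay on L6 cells (Rattus norvegicus) for cytotoxicity (on this read-out lower numbers stand for stronger inhibition and higher numbers for weaker inhibition), compound 1 gives 167000 nM, compound 2 gives 90700 nM and compound 3 gives 212000 nM. The gap between compound 1 and compound 2 lies within the usual scatter, as does the gap between compound 1 and compound 3, so no order among these three is claimed.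

Within the data shown here, the one change that is measured is a group of 6 heavy atoms (3 carbon, 3 nitrogen; one five-membered non-aromatic ring with 2 hetero atoms) in place of a hydrogen atom, on an aromatic carbon, and it brought a step of a 2.3-fold higher number from compound 2 to compound 3 (0.37 log units; beyond the scatter). The change from compound 1 to compound 4 is the same: a group of 6 heavy atoms (3 carbon, 3 nitrogen; one five-membered non-aromatic ring with 2 hetero atoms) in place of a hydrogen atom, on an aromatic carbon, at a place described in the same words. On that single precedent, the step from compound 1 to compound 4 in this assay is expected to be a 2.0-fold higher number from compound 1 to compound 4 (0.30 log units; within the scatter), beside the earlier one. The expectation rests on the step of a 2.3-fold higher number from compound 2 to compound 3 (0.37 log units; beyond the scatter) and on the value of compound 1 167000 nM as its start; with one precedent only, the range is kept wide. Compound 4 is estimated at 330000 nM in this assay, with a range from 150000 nM to 700000 nM.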

Compound 4, half-maximal inhibitory concentration: 41000 nM
For compound 4 the middle estimate is 8.0-fold (0.91 log units) above the measured one; the measured number lies below the stated range.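

In this assay, placing the second five-membered ring group on the core of compound 1 brought a 4.1-fold lower number from compound 1 to compound 4 (0.61 log units; beyond the scatter), and the same change does not carry from one core to the other in direction or in size: the same change on two cores in this assay, a 2.3-fold higher number (0.37 log units; beyond the scatter) from compound 2 to compound 3 and a 4.1-fold lower number (0.61 log units; beyond the scatter) from compound 1 to compound 4, 9.5-fold (0.98 log units) apart, beyond the scatter of two such steps In this series, a step measured on one of these two cores therefore gives no safe guide to the step on the other, and any estimate made that way needs a precedent on the same core. Among these compounds, what these results do not show is why the two steps part, since they measure no property that could separate the cores, and with only one pair per core they cannot tell which step is the more typical or what the change would do on a third core.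

Still open, from the compounds shown here alone, is whether the opposite steps belong to this particular ring group or would also appear with a simple amine or a carboxylic acid at the same place on both cores. Also open, going by these compounds, is whether a longer chain carrying the same ring group would give steps that agree across the two cores or stay as far apart as these do.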